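The source may report more compounds than this note shows. Statements on the series, on what has been measured and on what is new or still open speak of the compounds shown alone.

Measured so far in an assay on HEK293 cells for agonist activity at transient receptor potential cation channel subfamily M member 8 (Homo sapiens), read by fluorescence and calcium flux, with a stated time of 15 min; on this read-out higher numbers stand for an effect only at larger amounts of compound and lower numbers for an effect already at smaller amounts:

Compound 1, `CCN(Cc1cccs1)C(=O)c1cc2cc(C)ccc2[nH]1`, gives 2010 nM.
Compound 2, `Cc1ccc(OCC(=O)N(Cc2cccs2)C2CCCCC2)cc1`, gives 40000 nM.
Compound 3, `CCN(Cc1ccsc1)C(=O)COc1ccc(C)cc1`, gives 88 nM.

Among these three, compound 2 stands at the highest number, that is, it needs the largest amount to act. Its nearest neighbour is compound 1, and even that gap lies beyond the usual scatter; the distance to compound 3 is wider still. Compound 2 and compound 3 differ in more than one place, so their two values can be compared but no single cause can be read from them.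

The next compound, compound 4, `Cc1ccc(OCC(=O)N(Cc2cccs2)C(C)C)cc1`, changes compound 2 in one place only: isopropyl in place of cyclohexyl on an amide-type nitrogen. Compound 3, which carries ethyl on its amide-type nitrogen, shows the lowest number of the three, and compound 1, also with ethyl there, stands well below compound 2 as well. On that basis the move to a shorter group on the same nitrogen is expected to lower the number in this assay by a step beyond the scatter, though the rest of compound 4 is that of compound 2, not of compound 3. The expected step from compound 2 to compound 4 is a 6.7-fold lower number from compound 2 to compound 4 (0.82 log units; beyond the scatter). For compound 4 the estimate is 6000 nM, with a range from 1200 nM to 30000 nM.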

Compound 4, half-maximal effective concentration: 70 nM
Estimate against measurement, compound 4: 86-fold (1.93 log units) above, and the stated range ends above it.
By their numbers in this assay, from the lowest: compounds 4 and 3 (each within the scatter of the next); then compound 1; then compound 2.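

In this assay the swap of cyclohexyl for isopropyl on the amide-type nitrogen gives a 570-fold lower number from compound 2 to compound 4 (2.76 log units; beyond the scatter) and is the only difference between the two structures, so this single position can by itself move the number a very long way. The earlier compounds shown here could not show this, since no two of them differed in one place only, and the group on this nitrogen could not be separated from the rest of each structure. The change takes away the six-membered carbon ring and leaves fewer heavy atoms in this group, but nothing measured here explains why the number falls so far.

The compounds shown leave open where between isopropyl and cyclohexyl the number starts to climb, for instance with cyclopentyl or tert-butyl on this nitrogen. They also leave open whether methyl or a longer chain such as n-butyl would keep the number low with the rest of compound 4 unchanged.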